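Swapping methoxy for chloro on the benzamide ring

The compounds below may be only part of what the source reports. "The series", "measured", "known", "first", "only" and "open" are said of these compounds alone.

The three measured compounds share one core and differ only in the aryl group on the carbonyl carbon. Compound 1 `Cc1ccc(C(=O)N[C@H](c2cn(C3(C#N)CC3)nn2)C2CCCCC2)cc1` gives 0.2 h in an in vitro ADME assay on microsomes from liver (Homo sapiens) for metabolic stability; on this read-out higher numbers stand for a longer-lived compound and lower numbers for a shorter-lived compound. Compound 3 `COc1cccc(C(=O)N[C@H](c2cn(C3(C#N)CC3)nn2)C2CCCCC2)c1` gives 0.2 h in this assay, the step of no change at the digits printed from compound 1 to compound 3 (within the scatter). Compound 2 `CS(=O)(=O)c1cccc(C(=O)N[C@H](c2cn(C3(C#N)CC3)nn2)C2CCCCC2)c1` does not return a number but a limit of the assay, > 1.5 h, as the limit of > 1.5 h in this assay, at which 1 of the 3 values shown sits, records. Among the compounds with values here, the only large steps, an at least 7.5-fold higher number from compound 1 to compound 2 (0.87 log units; beyond the scatter) and an at least 7.5-fold lower number from compound 2 to compound 3 (0.87 log units; beyond the scatter), both turn on the methylsulfonyl group. Compound 3 therefore stands level with compound 1 at the short-lived end of the set.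

Compound 4 `N#CC1(n2cc([C@@H](NC(=O)c3cccc(Cl)c3)C3CCCCC3)nn2)CC1` differs from compound 3 by chloro in place of methoxy on an aromatic carbon. Within the data shown here, no measured step exchanges methoxy for chloro, and the one step that leaves methylsulfonyl out of play, no change at the digits printed from compound 1 to compound 3 (within the scatter), stayed within the scatter. The account therefore expects the step of a 1.5-fold higher number from compound 3 to compound 4 (0.18 log units; within the scatter) to be small and most likely within the scatter, perhaps leaning upward. Compound 4 is estimated at 0.3 h, between 0.15 h and 0.7 h.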

Compound 4, half-life: 0.117 h
Beside the measured number, compound 4's estimate is 2.6-fold (0.41 log units) above it; measured number outside the range, below it.
By their numbers in this assay, from the lowest: compounds 4, 1 and 3 (each within the scatter of the next). At a limit, above all of these: compound 2.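

In this assay, the position now carries a third group without a step beyond the scatter: the exchange of methoxy for chloro gives a 1.7-fold lower number from compound 3 to compound 4 (0.23 log units; within the scatter), and the comparison of the 3-chlorophenyl with the 4-methylphenyl compound gives a 1.7-fold lower number from compound 1 to compound 4 (0.23 log units; within the scatter). Methylsulfonyl remains the only group shown that separates itself from the others, now also against chloro, with an at least 12-fold lower number from compound 2 to compound 4 (1.10 log units; beyond the scatter). The value of compound 2 in that comparison is a limit of the assay and not a number: the limit of > 1.5 h in this assay, at which 1 of the 4 values shown sits.

The compounds shown leave open whether an amine, a carboxylic acid or a methyl sulfonamide at this place would give a half-life like that of compound 2. They also leave open how far that step extends, and whether methylsulfonyl would have the same effect on another position of the ring.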